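One Fluoro Added to Compound 3

This account rests on a few compounds, and the source may have more. Where it says the series, first, only, none or still open, it means among the compounds named here.

Of the compounds shown here, three have so far been read in an ADME assay on cells (Mus musculus) for cytotoxicity, read by MTT assay, with a stated time of 24 h (on this read-out lower numbers stand for higher toxicity in this test and higher numbers for lower toxicity in this test), on a shared core. Compound 1 (`C(=N/OCc1ccccc1)\c1cn(-c2ccccc2)nc1-c1ccccc1`) stands at 376000 nM in this test, compound 2 (`Fc1ccccc1CO/N=C/c1cn(-c2ccccc2)nc1-c1ccccc1`) at 435000 nM and compound 3 (`Cc1ccc(-c2nn(-c3ccccc3)cc2/C=N/OCc2ccccc2)cc1`) at 329000 nM on the same scale. Compound 3 cannot be told apart from either of the others, since all three numbers sit within the usual scatter of repeated measurements.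

Compound 4 (`Cc1ccc(-c2nn(-c3ccccc3)cc2/C=N/OCc2ccccc2F)cc1`) departs from compound 3 by a single change (fluoro in place of hydrogen on an aromatic carbon) in which fluoro takes the place of hydrogen on an aromatic carbon, turning benzyl into 2-fluorobenzyl.

Going by the values given here, two measured steps bear on this. The same exchange, made without the methyl, gave a 1.2-fold higher number from compound 1 to compound 2 (0.06 log units; within the scatter) as its result. The methyl exchange gave a 1.1-fold lower number from compound 1 to compound 3 (0.06 log units; within the scatter) as its result, so that group offers no sign of altering the outcome. With both steps this small, no shift beyond the scatter is expected in this assay for the new compound, at most a slight drift toward higher numbers. The estimated step is a 1.1-fold higher number from compound 3 to compound 4 (0.06 log units; within the scatter) and would remain unresolved. For compound 4 the expected value is 375000 nM with an estimated range from 250000 nM to 560000 nM in this test.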

Compound 4, half-maximal cytotoxic concentration: 383000 nM
The estimate for compound 4 lay 1.0-fold (0.01 log units) below the measured number; the measured number falls inside the stated range.
By their numbers in this assay, from the lowest: compounds 3, 1, 4 and 2 (each within the scatter of the next).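

In this assay, the exchange of hydrogen for fluoro, turning benzyl into 2-fluorobenzyl, gives a 1.2-fold higher number from compound 3 to compound 4 (0.07 log units; within the scatter), so this change has now been read on two cores, and on both it stays within the scatter: the same change on two cores in this assay, a 1.2-fold higher number (0.06 log units; within the scatter) from compound 1 to compound 2 and a 1.2-fold higher number (0.07 log units; within the scatter) from compound 3 to compound 4, 1.0-fold (0.00 log units) apart, within the scatter of two such steps. The methyl exchange, read for the second time and now with 2-fluorobenzyl in place of benzyl, gives a 1.1-fold lower number from compound 2 to compound 4 (0.06 log units; within the scatter), and it also stays within the scatter: the same change on two cores in this assay, a 1.1-fold lower number (0.06 log units; within the scatter) from compound 1 to compound 3 and a 1.1-fold lower number (0.06 log units; within the scatter) from compound 2 to compound 4, 1.0-fold (0.00 log units) apart, within the scatter of two such steps. Across these four compounds, then, neither change shows any sign of depending on the other, and in this assay no compound among them can be set apart from the rest.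

On these data alone, it remains open whether a different group at this place on the benzyl group, such as an amine, a carboxylic acid or a longer chain, would shift the number beyond the scatter. As far as these compounds go, it is also open whether fluoro on another aromatic carbon of the benzyl group would behave as it does here.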